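This account rests on a few compounds, and the source may have more. Where it says the series, first, only, none or still open, it means among the compounds named here.

Measured so far:
compound 1 `Cc1ccc(C#N)c(OC(C)(C)C2OCC(C/C=C\CCC(=O)O)C(c3cccnc3)O2)c1`: in an assay for inhibition of prostacyclin synthase (Homo sapiens), using microsomes (a lower number here means a stronger inhibitor, a higher number a weaker inhibitor), compound 1 gives > 100000 nM, a limit of the assay.
compound 2 `COc1ccc(OC(C)(C)C2OCC(C/C=C\CCC(=O)O)C(c3cccnc3)O2)cc1`: in this assay compound 2 gives > 100000 nM, again a limit of the assay.

For the measured compounds named here, both values are limits, so the one step between measured compounds, a step that the two limits leave unreadable from compound 1 to compound 2, has no readable size; (the limit of > 100000 nM in this assay, at which 2 of the 2 values shown sit). Going by the values given here, compound 2 therefore stands only at the limit of this assay, with no number of its own and no second compound that would anchor it.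

Compound 3 `CC(C)(Oc1ccc(F)cc1)C1OCC(C/C=C\CCC(=O)O)C(c2cccnc2)O1` differs from compound 2 by fluoro in place of methoxy on an aromatic carbon. Among the compounds with values here, the only measured step that bears on it, a step that the two limits leave unreadable from compound 1 to compound 2, concerns the substitution pattern of the same phenyl and is unreadable, so it gives no direction and no size for the present change. No step beyond the scatter is expected; the expected step is a step that the limit leaves unreadable from compound 2 to compound 3.

In this assay compound 3 is estimated at 150000 nM, with a range from 30000 nM to 1000000 nM, and it is expected that the assay will again report only a limit.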

Compound 3, half-maximal inhibitory concentration: 2000 nM
Compound 3: the middle estimate sits 75-fold (1.88 log units) above what was measured; measured number below the stated range.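

In this assay, for the compounds shown here, the aromatic carbon para to a large group proves to be a place where the read-out can move: fluoro in place of methoxy gives an at least 50-fold lower number from compound 2 to compound 3 (1.69 log units; beyond the scatter), the first step with a readable size. Exchanging the whole aryl group on the oxygen agrees with this, as 4-fluorophenyl in place of 2-cyano-5-methylphenyl gives an at least 50-fold lower number from compound 1 to compound 3 (1.69 log units; beyond the scatter), and compound 3, at 2000 nM, is the only compound shown with a number of its own. Both steps are minimum sizes, and the full size of each stays hidden: the limit of > 100000 nM in this assay, at which 2 of the 3 values shown sit.

Still open, on these data alone, is whether the change depends on fluoro itself or on the loss of methoxy, which a plain phenyl, a chloro or a trifluoromethyl group at that carbon would help to separate. Also open, as far as these compounds go, is how far the value of compound 3 depends on the rest of the shared core, for instance on a longer chain or an amide in place of the carboxylic acid.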